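Replacing 3-hydroxyphenyl with 4-methylphenyl at the assay limit

A few compounds are considered here, and "the series" means these few. Any claim that something is new, unique, unknown or untested is made for them only; others in the source may bear on it.

Of the compounds shown here, three sharing one core have so far been tested in a functional assay on HT29-AK cells (Homo sapiens) for cytotoxicity, read by MTT assay, with a stated time of 48 h (on this read-out lower numbers stand for stronger inhibition and higher numbers for weaker inhibition), and none has given a number. Compound 1 `COc1ccccc1Nc1nc(-c2cccc(F)c2)nc2ccc(F)cc12` reads > 50000 nM and this is a limit of the assay. Compound 2 `Fc1cccc(-c2nc(Nc3cccc(Br)c3)c3cc(F)ccc3n2)c1` reads > 50000 nM and this too is a limit. Compound 3 `Oc1cccc(Nc2nc(-c3cccc(F)c3)nc3ccc(F)cc23)c1` reads > 50000 nM and this is also a limit. Compound 3 therefore has no exact place on the scale and stands with the other two at the limit of > 50000 nM in this assay, at which 3 of the 3 values shown sit, without any ranking among them.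

The next compound is compound 4 `Cc1ccc(Nc2nc(-c3cccc(F)c3)nc3ccc(F)cc23)cc1` and the counted difference 4-methylphenyl in place of 3-hydroxyphenyl on a nitrogen on an aromatic ring amounts to 4-methylphenyl in place of 3-hydroxyphenyl on a nitrogen on an aromatic ring. Among the measured compounds shown here, three measured steps bear on this change, since each alters the group on that nitrogen or its substituent, yet a step that the two limits leave unreadable from compound 1 to compound 2 and a step that the two limits leave unreadable from compound 1 to compound 3 and a step that the two limits leave unreadable from compound 2 to compound 3 supply no size to carry over. None of the three compounds goes against a reading at the limit. The estimate for a number no higher from compound 3 to compound 4 (the limit leaves the size open) in this assay is therefore an expected change no larger than the scatter, with no direction favoured. For compound 4 the estimated value is 50000 nM with an expected range from 20000 nM to 100000 nM and the reading may well be a limit once more.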

Compound 4, half-maximal inhibitory concentration: > 50000 nM
Compound 4: only a limit was reported; the forecaster's own chance of this, stated with the estimate: 75%; the middle value lies on the limit itself.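

In this assay compound 4 gives > 50000 nM, and this is a limit of the assay. Its steps from compound 1, compound 2 and compound 3 therefore cannot be read, and all four compounds stand together: the limit of > 50000 nM in this assay, at which 4 of the 4 values shown sit.

The compounds shown leave open whether any group on that nitrogen gives a measurable number in this assay, and how these four would rank.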